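Chloro to methyl on the fused ring of compound 2

The source may hold more compounds than are shown below. What is called first, only, known or untested is meant among the compounds shown, and "the series" means these compounds.

Measured so far:
compound 1 `Cc1ccc2ncc(S(=O)(=O)c3ccc(Cl)cc3)c(N3CCC(C)CC3)c2c1`: 79%
compound 2 `Cc1ccc(S(=O)(=O)c2cnc3ccc(Cl)cc3c2N2CCC(C)CC2)cc1`: 95%

Both compounds were tested in an assay on isolated protein for displacement of a labelled ligand from metabotropic glutamate receptor 5 (Homo sapiens), with a stated time of 60 min, tested at 1 uM; on this read-out lower numbers stand for less inhibition and higher numbers for more inhibition at the one concentration tested (going by the name of the read-out). Compound 2 stands highest of the two numbers; compound 1 is the nearer neighbour and sits lower by a gap beyond the usual scatter. For the measured compounds named here, the two structures differ in more than one place, so no single step can be drawn between them, and nothing beyond the two values themselves is read into that gap.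

Compound 3 `Cc1ccc(S(=O)(=O)c2cnc3ccc(C)cc3c2N2CCC(C)CC2)cc1` has not yet been measured. It differs from compound 2 in one place: methyl in place of chloro on an aromatic carbon. The change keeps the size of the group and adds nothing that donates or accepts a hydrogen bond. With no measured step of this kind in the series, the expected step of a number 7 percentage points lower from compound 2 to compound 3 (within the scatter) is taken as small and downward, likely within the scatter. Compound 3 is therefore expected to give 88%, with a range from 70% to 98%.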

Compound 3, a percentage reported as inhibition, at one concentration (the size of the read-out at that concentration, not a potency): 82%
Compound 3: middle estimate off by 6 percentage points, on the high side; measured number inside the range.
By their numbers in this assay, from the lowest: compounds 1 and 3 (each within the scatter of the next); then compound 2.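

Chloro to methyl on the fused ring gives a number 13 percentage points lower from compound 2 to compound 3 (beyond the scatter) in this assay, the first step in the series that can be read at this aromatic carbon, and chloro and methyl are not interchangeable there. The same exchange at the other chloro-bearing aromatic carbon gives a number 3 percentage points higher from compound 1 to compound 3 (within the scatter), so in these two steps the read-out separates the groups at the fused ring only. Each conclusion rests on a single pair of compounds, and nothing available here bears on why the two places differ.

Open, going by these compounds, is whether fluoro, methoxy or a nitrile on this carbon would track the number seen with chloro or that seen with methyl. Also open, on these data alone, is how these steps relate to potency, as each number comes from one concentration.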